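The compounds below may be only part of what the source reports. "The series", "measured", "known", "first", "only" and "open" are said of these compounds alone.

Measured compounds:
compound 1, `CC(C)[C@H](C(=O)Nc1ncc(C(F)(F)F)s1)c1ccc(Cl)cc1`, with 95%
compound 2, `CC(C)(C)[C@H](C(=O)Nc1ncc(Br)s1)c1ccc(Cl)cc1`, with 95%

Both compounds were tested in a functional assay on CHO cells for agonist activity at Free fatty acid receptor 2 (Homo sapiens), read by cAMP accumulation; a higher number here means a larger maximal response, a lower number a smaller maximal response. In this assay compound 1 reaches 95%, and compound 2 reaches 95%. Compound 2 therefore stands level with compound 1 at the digits shown; the two values lie within the usual scatter of repeated measurements, so nothing separates them.

Compound 3, `CC(C)(C)[C@H](C(=O)Nc1ncc(C(F)(F)F)s1)c1ccc(Cl)cc1`, has not yet been measured. It differs from compound 2 in one place: trifluoromethyl in place of bromo on an aromatic carbon. The trifluoromethyl group that enters is the same group that compound 1 carries at that spot, and compound 1 shows no different maximal response from compound 2.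

Because both compound 1 with 95% and compound 2 with 95% give the same maximal response, the step from compound 2 to compound 3 is expected to be small, with no direction beyond the scatter; the expected step is no change at the digits printed from compound 2 to compound 3 (within the scatter). For compound 3 the estimated maximal response in this assay is 95%, with a range from 82% to 106%.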

Compound 3, largest response reached (reported as efficacy), in percent of the reference or control that the assay uses: 95%
Beside the measured number, compound 3's estimate shows no gap at the digits printed; the measured number falls inside the stated range.
By their numbers in this assay, from the lowest: compounds 1, 2 and 3 (each within the scatter of the next).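

In this assay, replacing bromo with trifluoromethyl on the aromatic carbon next to the ring sulfur gives no change at the digits printed from compound 2 to compound 3 (within the scatter), so this position accepts either group with no measurable difference in maximal response, even though the entering group has more heavy atoms. Compound 3 also completes a second single-place comparison: methyl in place of hydrogen on a saturated chain carbon bound to three saturated chain carbons gives no change at the digits printed from compound 1 to compound 3 (within the scatter), which shows that this chain change makes no measurable difference when trifluoromethyl sits on the aromatic carbon. No measurements are available that would explain why the maximal response stays level across these changes.

As far as these compounds go, all three compounds carry a halogen or a halogen-bearing group at this aromatic carbon, so it remains open whether a very different group there, such as an amine or a carboxylic acid, would give the same maximal response. These values also describe only the largest response reached, so they leave open how much of each compound is needed to reach it.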